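Trifluoromethyl to Bromo on an Aromatic Carbon

The source may report more compounds than this note shows. Statements on the series, on what has been measured and on what is new or still open speak of the compounds shown alone.

For the measured compounds named here, in a functional assay on MCF7 cells (Homo sapiens) for antiproliferative activity, read by MTT assay, with a stated time of 72 h (on this read-out lower numbers stand for stronger inhibition and higher numbers for weaker inhibition), compound 1 `O=S(=O)(Oc1ccccc1)C1CC2OC1C(c1ccc(/C=C/c3cc(O)cc(O)c3)cc1)=C2c1ccc(O)cc1` gives 20100 nM and compound 2 `O=S(=O)(Oc1cccc(C(F)(F)F)c1)C1CC2OC1C(c1ccc(/C=C/c3cc(O)cc(O)c3)cc1)=C2c1ccc(O)cc1` gives 11500 nM so compound 2 stands within the scatter of its only measured neighbour. Compound 3 `O=S(=O)(Oc1cccc(Br)c1)C1CC2OC1C(c1ccc(/C=C/c3cc(O)cc(O)c3)cc1)=C2c1ccc(O)cc1` has not yet been measured. Going by the values given here, it differs from compound 2 by bromo in place of trifluoromethyl on an aromatic carbon of a six-membered aromatic ring of carbon only, meta to a large group bromo in place of trifluoromethyl on an aromatic carbon and no measured compound carries bromo. Among the compounds with values here, the only measured step bearing on this change is a 1.7-fold lower number from compound 1 to compound 2 (0.24 log units; within the scatter) also on an aromatic carbon. On that evidence alone, no step beyond the scatter is expected in this assay for this exchange. The estimate is a 1.0-fold higher number from compound 2 to compound 3 (0.02 log units; within the scatter) as the expected step. For compound 3 the estimated value is 12000 nM with an expected range from 6000 nM to 24000 nM on this read-out.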

Compound 3, half-maximal inhibitory concentration: 19800 nM
For compound 3 the middle estimate is 1.7-fold (0.22 log units) below the measured one; measured number inside the range.
By their numbers in this assay, from the lowest: compounds 2, 3 and 1 (each within the scatter of the next).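

In this assay, the exchange of trifluoromethyl for bromo on this aromatic carbon gives a 1.7-fold higher number from compound 2 to compound 3 (0.24 log units; within the scatter) and leaves the read-out within the scatter. Bromo in place of hydrogen, read directly against the unsubstituted phenoxy compound, gives a 1.0-fold lower number from compound 1 to compound 3 (0.01 log units; within the scatter) and also stays within the scatter, so at this place neither the group of four heavy atoms nor the single bromine separates from hydrogen or from each other. No measured evidence is available to account for these values.

On these data alone, whether an amine, a carboxylic acid or a methoxy group at this same place would produce a step beyond the scatter remains open. The compounds shown also leave open whether bromo or trifluoromethyl would read the same elsewhere on this ring.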